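Hydroxyphenyl position change on the shared core

The source may report more compounds than this note shows. Statements on the series, on what has been measured and on what is new or still open speak of the compounds shown alone.

Compound 1 `COc1cc(-n2cnc3ccc(-c4ccc([N+](=O)[O-])cc4)cc32)cc(OC)c1OC` gives 79 nM in a functional assay on SGC-7901 cells (Homo sapiens) for antiproliferative activity, read by MTT assay, with a stated time of 72 h; a higher number here means a weaker inhibitor, a lower number a stronger inhibitor. Compound 2 `COc1cc(-n2cnc3ccc(-c4ccc(Cl)cc4Cl)cc32)cc(OC)c1OC` reaches only the limit of > 10000 nM in this assay. Compound 3 `COc1cc(-n2cnc3ccc(-c4ccc(O)cc4)cc32)cc(OC)c1OC` likewise sits at the limit of > 10000 nM in this assay. Both departures from compound 1 are large, an at least 120-fold higher number from compound 1 to compound 2 (2.10 log units; beyond the scatter) and an at least 120-fold higher number from compound 1 to compound 3 (2.10 log units; beyond the scatter), whereas a step that the two limits leave unreadable from compound 2 to compound 3, both values resting on (the limit of > 10000 nM in this assay, at which 2 of the 3 values shown sit). Compound 4 `COc1cc(-n2cnc3ccc(-c4cccc(O)c4)cc32)cc(OC)c1OC` carries 3-hydroxyphenyl in place of 4-hydroxyphenyl on an aromatic carbon. No measured step tests this change, and compound 3 offers only a limit, so no direction can be read from the numbers shown. The step of a number no higher from compound 3 to compound 4 (the limit leaves the size open) is therefore expected to stay near the limit. Compound 4 is estimated at 10000 nM, within 1500 nM to 30000 nM, most probably reported again as a limit.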

Compound 4, half-maximal inhibitory concentration: 53 nM
For compound 4 the middle estimate is 190-fold (2.28 log units) above the measured one; the whole stated range lies above it.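

Position of the hydroxy group decides the outcome here: with the same atoms joined differently, 3-hydroxyphenyl in place of 4-hydroxyphenyl gives an at least 180-fold lower number from compound 3 to compound 4 (2.27 log units; beyond the scatter) in this assay. The same group gives an at least 180-fold lower number from compound 2 to compound 4 (2.27 log units; beyond the scatter) against 2,4-dichlorophenyl, while against 4-nitrophenyl it gives a 1.5-fold lower number from compound 1 to compound 4 (0.17 log units; within the scatter), so 3-hydroxyphenyl and 4-nitrophenyl stand level. The values of compound 2 and compound 3 are limits, not numbers: the limit of > 10000 nM in this assay, at which 2 of the 4 values shown sit.

Going by these compounds, whether compound 4 keeps its 53 nM when an amine or a carboxylic acid replaces the hydroxy of its 3-hydroxyphenyl group stays open.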